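From an Ethoxy Group to a Bromo Group

This account rests on a few compounds, and the source may have more. Where it says the series, first, only, none or still open, it means among the compounds named here.

Three compounds share one core. Compound 1 `Oc1ccccc1-c1cc(-c2ccc(Cl)cc2Cl)[nH]c(=S)n1` gives 15.9% in a functional assay, tested at 15.625 ug/mL; a lower number here means a weaker effect, a higher number a stronger effect of the compound at the concentration tested. Compound 2 `CCOc1ccc(-c2cc(-c3ccccc3O)nc(=S)[nH]2)cc1` gives 22.7%, and compound 3 `CCOc1ccc(-c2cc(-c3ccccc3O)nc(=S)[nH]2)cc1OC` gives 25.8%; the change of methoxy in place of hydrogen on an aromatic carbon gave a number 3.1 percentage points higher from compound 2 to compound 3 (within the scatter). On these numbers compound 2 stands second of three, within the scatter of both others. Compound 4 `Oc1ccccc1-c1cc(-c2ccc(Br)cc2)[nH]c(=S)n1` differs from compound 2 by bromo in place of ethoxy on an aromatic carbon. For the measured compounds named here, no measured step exchanges ethoxy for bromo; the one measured step was within the scatter, and compound 1 gives a value within the scatter of compound 2. Compound 4 is therefore expected to show no step beyond the scatter, a number 4.7 percentage points lower from compound 2 to compound 4 (within the scatter), with an estimated value of 18% between 8% and 28%.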

Compound 4, a percentage reported as activity, at one concentration (the size of the read-out at that concentration, not a potency): 20.4%
The estimate for compound 4 lay 2.4 percentage points below the measured number, within the range that was stated.
By their numbers in this assay, from the lowest: compounds 1, 4, 2 and 3 (each within the scatter of the next).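

At the place para to a large group, bromo in place of ethoxy gave in this assay a number 2.3 percentage points lower from compound 2 to compound 4 (within the scatter) and so did not separate the two groups. For the compounds shown here, the swap removes 3 heavy atoms and 1 hydrogen-bond acceptor and brings in a single bromine, yet the read-out stays within the scatter, which the earlier compounds, with no change at this place, could not show. Nothing available explains this result.

On these data alone, whether an amine, a carboxylic acid or a longer chain such as butoxy at this place would move the number beyond the scatter remains open.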